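The compounds below may be only part of what the source reports. "The series", "measured", "known", "first", "only" and "open" are said of these compounds alone.

Compound 1 `NC(=O)c1c(NC(=O)c2ccccc2Cl)sc2c1CCNC2` gives 28700 nM in a functional assay on MKN-74 cells (Homo sapiens) for antiproliferative activity, with a stated time of 24 h; on this read-out lower numbers stand for stronger inhibition and higher numbers for weaker inhibition. Within the data shown here, compound 2 `NC(=O)c1c(NC(=O)c2ccccc2Cl)sc2c1CCN(Cc1ccccc1Cl)C2` gives 4430 nM, the lower of the two numbers; the one step measured so far, a 6.5-fold lower number from compound 1 to compound 2 (0.81 log units; beyond the scatter), is the sole change recorded. Compound 3 `NC(=O)c1c(NC(=O)c2ccccc2Cl)sc2c1CCN(Cc1cc(Cl)cc(Cl)c1)C2` carries 3,5-dichlorophenyl in place of 2-chlorophenyl on a saturated chain carbon bound to an amine nitrogen in a ring. Among the measured compounds shown here, no measured step alters the substitution of this ring, so the recorded step gives no direct guide, and the expectation for compound 3 is a step of a 1.1-fold lower number from compound 2 to compound 3 (0.04 log units; within the scatter), not beyond the scatter. Compound 3 is therefore estimated at 4000 nM, within 1500 nM to 12000 nM.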

Compound 3, half-maximal inhibitory concentration: 23700 nM
The estimate for compound 3 lay 5.9-fold (0.77 log units) below the measured number; measured number above the stated range.
By their numbers in this assay, from the lowest: compound 2; then compounds 3 and 1 (each within the scatter of the next).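

Putting a benzyl group on the amine nitrogen in a ring does not by itself carry the gain: with 3,5-dichlorobenzyl, the number stays level with that of compound 1 (a 1.2-fold lower number from compound 1 to compound 3 (0.08 log units; within the scatter)). Replacing 2-chlorophenyl with 3,5-dichlorophenyl gives up what compound 2 had gained (a 5.3-fold higher number from compound 2 to compound 3 (0.73 log units; beyond the scatter)), so in this assay the outcome at this position depends on the chlorine substitution of the benzyl group. Nothing available accounts for this difference. From the compounds shown here alone, whether the number of compound 2 requires chlorine at all stays open; a plain benzyl or a methoxybenzyl on the same nitrogen would bear on that.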